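A few compounds are considered here, and "the series" means these few. Any claim that something is new, unique, unknown or untested is made for them only; others in the source may bear on it.

Measured compounds in a functional assay on DU-145 cells (Homo sapiens) for inhibition, read by sulforhodamine B assay, with a stated time of 48 h; a lower number here means a stronger inhibitor of growth, a higher number a weaker inhibitor of growth:
compound 1 `Nc1cc(N)c2nc(-c3ccccc3)c(Oc3ccc(Cl)c(Cl)c3)nc2c1` gives 29500 nM
compound 2 `CCOC(=O)[C@H](CCC(=O)O)NC(=O)c1ccc(Sc2nc3cc(N)cc(N)c3nc2-c2ccccc2)cc1` gives 69200 nM

Compound 1 holds the lower of the two numbers; the value of compound 2 lies above it, beyond the scatter. Compound 2 carries a different side chain altogether, so the two values do not isolate any single change.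

Compound 3 `Nc1cc(N)c2nc(-c3ccccc3)c(Sc3ccc(Cl)c(Cl)c3)nc2c1` has not yet been measured in this assay. It differs from compound 1 in one place:
(3,4-dichlorophenyl)sulfanyl in place of 3,4-dichlorophenoxy on an aromatic carbon
The shared core, the phenyl group and the two amino groups stay as they are; only the linking atom between the dichlorinated ring and the core is exchanged. Among the compounds with values here, no measured pair in this set isolates such an exchange, so its effect is not known from these data. For the step of a 1.2-fold higher number from compound 1 to compound 3 (0.07 log units; within the scatter) the expectation is a small one, within the scatter, with no direction preferred. Compound 3 is estimated at 35000 nM, with a range from 12000 nM to 100000 nM.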

Compound 3, concentration for 50% growth inhibition: 1510 nM
Beside the measured number, compound 3's estimate is 23-fold (1.37 log units) above it, and the stated range ends above it.
By their numbers in this assay, from the lowest: compound 3; then compound 1; then compound 2.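

The linking atom at this position matters in this assay and is not a silent exchange: (3,4-dichlorophenyl)sulfanyl in place of 3,4-dichlorophenoxy gives a 20-fold lower number from compound 1 to compound 3 (1.29 log units; beyond the scatter) with the rest of the molecule unchanged. The two groups have the same heavy-atom count, the same ring and the same counted hydrogen-bond donors and acceptors, so these counts do not separate them, and the step follows the exchange of oxygen for sulfur alone. No available measurement gives a reason for a step of this size.

Still open, going by these compounds, is how an amine or a methylene link at the same aromatic carbon would compare with the oxygen and sulfur links. Also open, on these data alone, is whether the sulfur-linked series keeps its number when the two chlorine atoms are replaced by a methoxy group or a carboxylic acid.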